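The source may report more compounds than this note shows. Statements on the series, on what has been measured and on what is new or still open speak of the compounds shown alone.

Among the compounds with values here, in a functional assay on C8166 cells (Homo sapiens) for cytotoxicity, read by MTT assay (a lower number here means that less compound is tolerated, a higher number that more compound is tolerated), compound 1 `Cc1ccc(C(=O)Nc2cc(Cl)ccc2OCC(=O)Nc2ccc(S(N)(=O)=O)cc2C)c(C)c1` gives 47600 nM while compound 2 `Cc1cc(S(N)(=O)=O)ccc1NC(=O)COc1ccc(Cl)cc1NC(=O)c1cc(Cl)cc(Cl)c1` gives 72400 nM and these two values lie within the usual scatter of each other, so compound 2 does not stand apart from the only other number measured. Within the data shown here, the one measured step that bears on the next change is a 1.5-fold higher number from compound 1 to compound 2 (0.18 log units; within the scatter) for 3,5-dichlorophenyl in place of 2,4-dimethylphenyl on a carbonyl carbon. Compound 3 `Cc1cc(S(N)(=O)=O)ccc1NC(=O)COc1ccc(Cl)cc1NC(=O)c1cccc2ccccc12` changes that same place again, with naphthalen-1-yl in place of 3,5-dichlorophenyl on a carbonyl carbon as the counted difference: naphthalen-1-yl in place of 3,5-dichlorophenyl on a carbonyl carbon. Among the measured compounds shown here, one small step is thin evidence, and no naphthalen-1-yl compound has been measured yet, so in this assay no step beyond the scatter is expected. The estimate amounts to a 1.2-fold lower number from compound 2 to compound 3 (0.08 log units; within the scatter) for this change. For compound 3 the estimated value is 60000 nM with 25000 nM to 130000 nM as the expected range.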

Compound 3, half-maximal cytotoxic concentration: > 381000 nM
Compound 3: only a limit was reported; the forecaster's own chance of this, stated with the estimate: 15%; middle value at least 6.3-fold (0.80 log units) from the limit.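

Swapping the group on the carbonyl carbon can move the number in this assay beyond the scatter after all: naphthalen-1-yl gives an at least 5.2-fold higher number from compound 2 to compound 3 (0.72 log units; beyond the scatter), and an at least 8.0-fold higher number from compound 1 to compound 3 (0.90 log units; beyond the scatter). Compounds 1 and 2 had suggested that this position made little difference, since 3,5-dichlorophenyl and 2,4-dimethylphenyl stayed within the scatter of each other, whereas a group with 2 six-membered aromatic rings does separate from both. For compound 3 the reported figure is only a limit: the limit of > 381000 nM in this assay, at which 1 of the 3 values shown sits.

Still open, going by these compounds, is whether the step follows the second ring or the loss of the two chlorines, as compound 3 differs from compound 2 in both. The compounds shown also say nothing about how an amine or a carboxylic acid on a phenyl group at this carbonyl carbon would read.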